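The source may report more compounds than this note shows. Statements on the series, on what has been measured and on what is new or still open speak of the compounds shown alone.

In a functional assay on brain (Rattus norvegicus, strain Wistar) for inhibition (a lower number here means a stronger inhibitor, a higher number a weaker inhibitor), compound 1 (`CCCCc1ccc(-c2c(C)[nH]c(=O)n2C2CCCCC2)cc1`) gives 27100 nM and compound 2 (`CCCCOc1ccc(-c2c(C)[nH]c(=O)n2C2CCCCC2)cc1`) gives 13900 nM while compound 3 (`CCCCCCc1ccc(-c2c(C)[nH]c(=O)n2C2CCCCC2)cc1`) gives 13700 nM and so stands within the scatter of both. Compound 4 (`CCCCCCCCOc1ccc(-c2c(C)[nH]c(=O)n2C2CCCCC2)cc1`) carries octyloxy in place of hexyl on an aromatic carbon. Among the compounds with values here, three measured steps bear on this, all within the scatter: a 1.9-fold lower number from compound 1 to compound 2 (0.29 log units; within the scatter) and a 2.0-fold lower number from compound 1 to compound 3 (0.30 log units; within the scatter) run the same way, while a 1.0-fold lower number from compound 2 to compound 3 (0.01 log units; within the scatter) is smaller still. On that basis only a small step toward a lower number is expected in this assay, not clearly beyond the scatter (a 1.5-fold lower number from compound 3 to compound 4 (0.18 log units; within the scatter) is the estimate). Compound 4 is expected at 9000 nM within an estimated range of 4000 nM to 20000 nM in this measurement.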

Compound 4, half-maximal inhibitory concentration: 8500 nM
The estimate for compound 4 lay 1.1-fold (0.02 log units) above the measured number; the range from low to high includes it.
By their numbers in this assay, from the lowest: compounds 4, 3, 2 and 1 (each within the scatter of the next, the first and the last beyond it).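

Within the data shown here, at this position in this assay, octyloxy gives the first step that clears the scatter, and a 3.2-fold lower number from compound 1 to compound 4 (0.50 log units; beyond the scatter) is still only modest. With a 1.6-fold lower number from compound 3 to compound 4 (0.21 log units; within the scatter) and a 1.6-fold lower number from compound 2 to compound 4 (0.21 log units; within the scatter) both within the scatter, octyloxy cannot be told apart from hexyl or butoxy here. Nothing at hand explains these numbers. On these data alone, how a longer chain, or an amine at the end of the chain, would fare in this assay stays open.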